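Fluorine on the Aryl Group: an Expectation for Compound 4

The source may report more compounds than this note shows. Statements on the series, on what has been measured and on what is new or still open speak of the compounds shown alone.

Compound 1 `Cc1ccc2c(C3CCN(CCN4CCN(C(C)C)C4=O)CC3)c[nH]c2c1`: 27 nM
Compound 2 `Cc1ccc2c(C3CCN(CCN4CCN(C(C)C)C4=O)CC3)cn(-c3ccc(Cl)cc3)c2c1`: 450 nM
Compound 3 `Cc1ccc2c(C3CCN(CCN4CCN(C(C)C)C4=O)CC3)cn(-c3ccccc3)c2c1`: 120 nM

In an assay on cell membranes for displacement of a labelled ligand from Adrenergic receptor alpha-1 (Rattus norvegicus) (on this read-out higher numbers stand for weaker inhibition and lower numbers for stronger inhibition), compound 3 gives 120 nM, the second highest number of the three: it sits a 3.8-fold lower number from compound 2 to compound 3 (0.57 log units; beyond the scatter) and a 4.4-fold higher number from compound 1 to compound 3 (0.65 log units; beyond the scatter). Compound 4 `Cc1ccc2c(C3CCN(CCN4CCN(C(C)C)C4=O)CC3)cn(-c3cccc(F)c3)c2c1` differs from compound 3 by fluoro in place of hydrogen on an aromatic carbon. The step that bears most directly on this is the halogen on the aryl ring, where the number moved a 3.8-fold lower number from compound 2 to compound 3 (0.57 log units; beyond the scatter); a chloro on that ring thus raised the number, and a 17-fold higher number from compound 1 to compound 2 (1.22 log units; beyond the scatter) points the same way. A fluoro is a smaller halogen, so a modest rise, smaller than that of chloro, is expected: a 1.7-fold higher number from compound 3 to compound 4 (0.22 log units; within the scatter). Compound 4 is estimated at 200 nM, with a range of 100 nM to 450 nM.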

Compound 4, half-maximal inhibitory concentration: 670 nM
Compound 4: the middle estimate sits 3.4-fold (0.53 log units) below what was measured, outside the stated range (above it).
By their numbers in this assay, from the lowest: compound 1; then compound 3; then compounds 2 and 4 (each within the scatter of the next).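

In this assay, a single fluoro on the phenyl ring is not a small change, giving a 5.6-fold higher number from compound 3 to compound 4 (0.75 log units; beyond the scatter). The two halogenated aryl groups are not separated, with a 1.5-fold higher number from compound 2 to compound 4 (0.17 log units; within the scatter), so a smaller halogen at a different place on the ring offers no gain here. Relative to hydrogen on the aromatic nitrogen, the 3-fluorophenyl group gives a 25-fold higher number from compound 1 to compound 4 (1.39 log units; beyond the scatter). Nothing available explains why the fluoro has this effect. As far as these compounds go, whether a methoxy or hydroxyl group in place of the fluoro would also raise the number remains open.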